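Two Limits on One Core, and a Third Aryl Group

The source may report more compounds than this note shows. Statements on the series, on what has been measured and on what is new or still open speak of the compounds shown alone.

In a functional assay on HepG2 cells (Homo sapiens) for antiproliferative activity, read by MTT assay, with a stated time of 48 h (on this read-out higher numbers stand for weaker inhibition and lower numbers for stronger inhibition), compound 1 `Cc1ccc(-n2nncc2CN2C(=O)C3(C(C#N)=C(N)Oc4c(N)cc5nc6ccccc6nc5c43)c3ccccc32)cc1C` gives only the assay limit > 50000 nM. Compound 2 `N#CC1=C(N)Oc2c(N)cc3nc4ccccc4nc3c2C12C(=O)N(Cc1cnnn1-c1ccc(Cl)cc1Cl)c1ccccc12` likewise reaches only the limit > 50000 nM in this assay. The step that the two limits leave unreadable from compound 1 to compound 2 therefore cannot be sized; what the two compounds share is the limit of > 50000 nM in this assay, at which 2 of the 2 values shown sit. Compound 3 `COc1ccc(OC)c(-n2nncc2CN2C(=O)C3(C(C#N)=C(N)Oc4c(N)cc5nc6ccccc6nc5c43)c3ccccc32)c1` carries the change (2,5-dimethoxyphenyl in place of 2,4-dichlorophenyl on an aromatic nitrogen). Going by the values given here, no measured step with a readable size bears on this change, so no shift beyond the usual scatter is expected, and a limit again seems likely. Compound 3 is estimated at 60000 nM, between 20000 nM and 200000 nM. The expected step is a step that the limit leaves unreadable from compound 2 to compound 3.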

Compound 3, half-maximal inhibitory concentration: 45100 nM
Beside the measured number, compound 3's estimate is 1.3-fold (0.12 log units) above it; low and high end bracket the measured number.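

Compound 3 is the only one of the three with a readable value at this position: in this assay compound 3 gives 45100 nM. Measured against the two limits, swapping the aryl group gives an at least 1.1-fold lower number from compound 2 to compound 3 (0.04 log units; that floor lies within the scatter), and also an at least 1.1-fold lower number from compound 1 to compound 3 (0.04 log units; that floor lies within the scatter), so neither comparison shows a real change. The two other compounds stay unsized: the limit of > 50000 nM in this assay, at which 2 of the 3 values shown sit.

As far as these compounds go, whether the oxygen atoms of the two methoxy groups matter remains open. So does whether a phenyl ring carrying an amine or a carboxylic acid would give a clearly lower number.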